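The source may report more compounds than this note shows. Statements on the series, on what has been measured and on what is new or still open speak of the compounds shown alone.

Compound 1 `Cc1cc(=O)n(-c2ccc(F)cc2)nc1C(=O)Nc1ccc(Oc2ncnc3ccsc23)cc1`: 2110 nM
Compound 2 `Cc1cc(=O)n(-c2ccccc2OC(F)(F)F)nc1C(=O)Nc1ccc(Oc2ncnc3ccsc23)c(F)c1`: 15700 nM

In a functional assay on HepG2 cells (Homo sapiens) for cytotoxicity, read by MTT assay, with a stated time of 72 h (on this read-out higher numbers stand for weaker inhibition and lower numbers for stronger inhibition), compound 2 gives 15700 nM, the highest of the two numbers; the nearest is compound 1, which gives 2110 nM, a gap beyond the scatter. Compound 3 `Cc1cc(=O)n(-c2ccc(F)cc2)nc1C(=O)Nc1ccc(Oc2ncnc3ccsc23)c(F)c1` arises from compound 2 through (4-fluorophenyl in place of 2-(trifluoromethoxy)phenyl on an aromatic nitrogen), 4-fluorophenyl in place of 2-(trifluoromethoxy)phenyl on an aromatic nitrogen. This is the group that compound 1 carries on an aromatic nitrogen, and compound 1 stands at 2110 nM in this assay. Compound 3 still differs from compound 1 elsewhere. For compound 3 the expected step is therefore a 4.1-fold lower number from compound 2 to compound 3 (0.62 log units; beyond the scatter), an estimated partial move toward the number of compound 1. Compound 3 is estimated at 3800 nM, within 1300 nM to 11000 nM.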

Compound 3, half-maximal inhibitory concentration: 470 nM
Compound 3: middle estimate off by 8.1-fold (0.91 log units), on the high side; the measured number lies below the stated range.
By their numbers in this assay, from the lowest: compound 3; then compound 1; then compound 2.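

In this assay, 4-fluorophenyl in place of 2-(trifluoromethoxy)phenyl on the aromatic nitrogen gives a 33-fold lower number from compound 2 to compound 3 (1.52 log units; beyond the scatter), showing that the group at this position strongly sets the number when the rest of the molecule is unchanged. With 4-fluorophenyl held there, fluoro in place of hydrogen on an aromatic carbon gives a 4.5-fold lower number from compound 1 to compound 3 (0.65 log units; beyond the scatter), a modest further gain. No measurement here accounts for either step.

Going by these compounds, it remains open whether the fluoro gain would also appear with 2-(trifluoromethoxy)phenyl on the nitrogen. On these data alone, the effect of an amine or a carboxylic acid on that phenyl ring also remains open.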